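A few compounds are considered here, and "the series" means these few. Any claim that something is new, unique, unknown or untested is made for them only; others in the source may bear on it.

Measured so far in a functional assay on CHO-K1 cells for agonist activity at Glucose-dependent insulinotropic receptor (Homo sapiens), read by cAMP accumulation and immunoassay, with a stated time of 1 h; a lower number here means that less compound is needed, a higher number that more compound is needed for the effect:
compound 1 `Cc1c(Oc2cccc(/C=C3\SC(=O)NC3=O)c2)ncnc1OC1CCN(C(=O)OCc2ccccc2)CC1` gives 106 nM
compound 2 `COC(=O)N1CCC(Oc2cc(Oc3cccc(/C=C4\SC(=O)NC4=O)c3)ncn2)CC1` gives 1870 nM

Among the compounds with values here, compound 2 stands at the higher of the two numbers; the gap to compound 1 lies beyond the scatter, and the two compounds differ in more than one place, so no single step is defined between them.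

Compound 3 `CCOC(=O)N1CCC(Oc2cc(Oc3cccc(/C=C4\SC(=O)NC4=O)c3)ncn2)CC1` differs from compound 2 by methyl in place of hydrogen on a saturated chain carbon bound to an oxygen next to a carbonyl group. Within the data shown here, no measured step of this kind exists, so the change is expected to stay within the scatter, with at most a slight move toward a lower number: a 1.4-fold lower number from compound 2 to compound 3 (0.16 log units; within the scatter). For compound 3 the expected value in this assay is 1300 nM, with a range from 450 nM to 3800 nM.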

Compound 3, half-maximal effective concentration: 819 nM
The estimate for compound 3 lay 1.6-fold (0.20 log units) above the measured number; measured number inside the range.
By their numbers in this assay, from the lowest: compound 1; then compound 3; then compound 2.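

In this assay, within the data shown here, methoxycarbonyl to ethoxycarbonyl gives a 2.3-fold lower number from compound 2 to compound 3 (0.36 log units; beyond the scatter), the first step that can be read at a single place. The carbamate end therefore responds to even one added methyl on a saturated chain carbon bound to an oxygen next to a carbonyl group, though the step is modest. No available data account for this step. From the compounds shown here alone, whether a longer chain, as in propoxycarbonyl, extends the move remains open. So does whether an amide or a simple amine at this place would keep the effect.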